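Fluoro to chloro on the benzoxazole of compound 2

A few compounds are considered here, and "the series" means these few. Any claim that something is new, unique, unknown or untested is made for them only; others in the source may bear on it.

Measured so far:
compound 1 `Cc1cc(-c2nc3cc(F)ccc3o2)ccc1NC(=O)CN1CCN(CCN(C)C)CC1` — 9460 nM
compound 2 `Cc1cc(-c2nc3cc(F)ccc3o2)ccc1NC(=O)CN1CCN(CCCN(C)C)CC1` — 7150 nM
compound 3 `CN(C)CCCN1CCN(CC(=O)Nc2ccc(-c3nc4cc(F)ccc4o3)cc2)CC1` — 9180 nM

All three values come from a functional assay on HepG2 cells (Homo sapiens) for cytotoxicity, read by MTT assay, with a stated time of 24 h; a lower number here means a stronger inhibitor, a higher number a weaker inhibitor. Compound 2 stands level with its two neighbours: the change a 1.3-fold lower number from compound 1 to compound 2 (0.12 log units; within the scatter) and the change a 1.3-fold higher number from compound 2 to compound 3 (0.11 log units; within the scatter) are both within the scatter, so the three compounds cannot be told apart on these numbers.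

Compound 4 `Cc1cc(-c2nc3cc(Cl)ccc3o2)ccc1NC(=O)CN1CCN(CCCN(C)C)CC1` is not yet measured. It differs from compound 2 in one place: chloro in place of fluoro on an aromatic carbon. Neither measured step bears directly on this change. Going by the values given here, the step from compound 1 to compound 2 concerns the chain on the ring amine nitrogen, and the step from compound 2 to compound 3 concerns a methyl on an aromatic carbon; no measured pair swaps one halogen for another on the fused ring. What the series does show is that two single changes elsewhere in the molecule each moved this assay by less than the scatter, and nothing in the data points to a larger effect here.

The expectation for compound 4 is therefore no step beyond the scatter, a 1.0-fold higher number from compound 2 to compound 4 (0.02 log units; within the scatter), and an estimated value of 7500 nM with a range from 3500 nM to 16000 nM.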

Compound 4, half-maximal inhibitory concentration: 11200 nM
Compound 4: the middle estimate sits 1.5-fold (0.17 log units) below what was measured; measured number inside the range.
By their numbers in this assay, from the lowest: compounds 2, 3, 1 and 4 (each within the scatter of the next).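

In this assay the halogen swap gives a 1.6-fold higher number from compound 2 to compound 4 (0.19 log units; within the scatter) and so joins the two earlier single changes around compound 2 as a step that stays within the scatter. Going by these compounds alone, the earlier compounds spoke only to the chain on the ring amine nitrogen and to the methyl on an aromatic carbon, whereas this pair gives the first reading on the fused ring: 5-fluoro-1,3-benzoxazol-2-yl and 5-chloro-1,3-benzoxazol-2-yl cannot be told apart on these numbers. No supporting measurement is available to explain how this position behaves in the cell assay.

A single exchange of one halogen for another leaves open what hydrogen, methoxy, trifluoromethyl or a nitrile would give on this same aromatic carbon, and what a halogen would give elsewhere on the fused ring. Also open, on these data alone, is whether any such group, or a carboxylic acid or a morpholine in place of the dimethylamino end of the chain, would produce a step beyond the scatter in this assay at all.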